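Chalcone series on prostate cancer cells: a chloro analogue

The source may report more compounds than this note shows. Statements on the series, on what has been measured and on what is new or still open speak of the compounds shown alone.

Measured so far:
compound 1 `COc1cccc(/C=C/C(=O)c2c(OC)cc(OC)cc2OC)c1` — 23%
compound 2 `COc1cc(O)c(C(=O)/C=C/c2ccccc2OC)c(OC)c1` — 36%

Both compounds were run in a functional assay on PC-3 cells (Homo sapiens), read by fluorescence and BrdU incorporation, with a stated time of 48 h, tested at 10 uM; on this read-out lower numbers stand for a stronger effect and higher numbers for a weaker effect at the one concentration tested. In this assay compound 1 gives 23%, the lowest of the two numbers; compound 2 gives 36%, and the gap between the two lies beyond the usual scatter of repeated measurements. For the measured compounds named here, the two measured compounds differ in more than one place, so no single-point step between them can be drawn and nothing is known about the weight of any one change.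

Compound 3 `COc1cc(OC)c(C(=O)/C=C/c2ccc(Cl)cc2)c(OC)c1` has not yet been measured in this assay. It differs from compound 1 by 4-chlorophenyl in place of 3-methoxyphenyl on a double-bonded chain carbon bound to a double-bonded chain carbon. Neither measured compound carries this change, so the two numbers offer no guide to its direction. The step is expected to be small, within or just beyond the scatter, and in either direction; the estimate amounts to a number 7 percentage points higher from compound 1 to compound 3 (within the scatter). For compound 3 the expected read-out is 30%, with a range from 15% to 50%.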

Compound 3, a percentage reported as activity, at one concentration (the size of the read-out at that concentration, not a potency): 15%
Compound 3: middle estimate off by 15 percentage points, on the high side; the measured number falls inside the stated range.
By their numbers in this assay, from the lowest: compounds 3 and 1 (each within the scatter of the next); then compound 2.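

For the compounds shown here, replacing 3-methoxyphenyl with 4-chlorophenyl on a double-bonded chain carbon bound to a double-bonded chain carbon gives the first single-place step: in this assay, the change amounts to a number 8 percentage points lower from compound 1 to compound 3 (within the scatter). This position therefore accepts an exchange that removes the methoxy oxygen, with its hydrogen-bond acceptor, and brings in chlorine, while compound 1 and compound 3 remain indistinguishable on this read-out. No measured property bears on this result, so the step stands as an observation without an explanation.

Going by these compounds alone, the single step changes the substituent and its place on the phenyl ring together, so the contribution of chlorine cannot be separated from that of its location, and a 3-chlorophenyl or 4-methoxyphenyl partner would be needed to divide the two. Also open, going by these compounds, is how far this position tolerates a different kind of substituent, such as a dimethylamino group or a carboxylic acid on the phenyl ring, and whether the similar read-outs at the one concentration tested would persist at other concentrations.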